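Adding a Second Methoxy to a Forced Swim Test Lead

The source may hold more compounds than are shown below. What is called first, only, known or untested is meant among the compounds shown, and "the series" means these compounds.

Of the compounds shown here, three built on one shared core have been tested in a functional assay on the whole organism (strain Swiss albino) with Mus musculus as the target, in the forced swim test, with a stated time of 5 min, at a dose of 0.5 mg/kg by the intraperitoneal route; on this read-out higher numbers stand for more inhibition at the one dose given (going by the name of the read-out) and lower numbers for less inhibition. Compound 1 `COc1ccc(-c2cc3cc(C4C(C#N)=C(N)OC5=C4C(=O)CC(C)(C)C5)cc(C(C)C)c3oc2=O)cc1` gives 64.9%, which is the second highest of the three numbers. Compound 3 `COc1ccc(-c2cc3cc(C4C(C#N)=C(N)OC5=C4C(=O)CCC5)cc(C(C)C)c3oc2=O)cc1` gives 69.7%, and its gap to compound 1 lies within the usual scatter, so the two cannot be told apart on these numbers. Compound 2 `COc1cc(-c2cc3cc(C4C(C#N)=C(N)OC5=C4C(=O)CCC5)cc(C)c3oc2=O)cc(OC)c1OC` differs from compound 1 in several places at once. Compound 2 gives 5.22%, far below compound 1 and beyond the scatter.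

The next compound, compound 4 `COc1ccc(-c2cc3cc(C4C(C#N)=C(N)OC5=C4C(=O)CC(C)(C)C5)cc(C(C)C)c3oc2=O)cc1OC`, differs from compound 1 in a single spot: methoxy in place of hydrogen on an aromatic carbon. Cut one bond further out, the same change reads as 4-methoxyphenyl to 3,4-dimethoxyphenyl.

Among the measured compounds shown here, no step between two measured compounds isolates this change, so the expectation rests on the shape of the set alone. For the measured compounds named here, compound 1 and compound 3 sit at the same level, while the only compound carrying more methoxy groups, compound 2, sits very low, though for several reasons at once. For compound 4 the expected step is a number 12.9 percentage points lower from compound 1 to compound 4 (beyond the scatter), a modest fall that may not clear the scatter. Compound 4 is therefore estimated at 52%, with a range from 20% to 75%.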

Compound 4, a percentage reported as inhibition, in the whole organism at one dose (the size of the read-out at that dose, not a potency): 86.6%
The estimate for compound 4 lay 34.6 percentage points below the measured number; measured number above the stated range.
By their numbers in this assay, from the lowest: compound 2; then compounds 1 and 3 (each within the scatter of the next); then compound 4.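

In this assay, among the compounds shown here, the change from 4-methoxyphenyl to 3,4-dimethoxyphenyl gives the first clean reading at this position, an aromatic carbon ortho to a methoxy group, and the result is a number 21.7 percentage points higher from compound 1 to compound 4 (beyond the scatter). This shows that, on the core of compound 1, this position takes a methoxy group in place of hydrogen with a gain rather than a loss on this read-out, so a second methoxy group is not enough on its own to account for the low number of compound 2, which differs from compound 1 in several places at once. Nothing at hand explains why the number rises.

As far as these compounds go, it remains open whether this rise belongs to methoxy itself, since a hydroxyl, an ethoxy or a chlorine on the same aromatic carbon would show whether other groups there move the number in the same way. The compounds shown also leave open whether the same change would carry over to compound 3, which holds the same 4-methoxyphenyl group on a different core.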